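The source may hold more compounds than are shown below. What is called first, only, known or untested is meant among the compounds shown, and "the series" means these compounds.

In an ADME assay on microsomes from liver (Rattus norvegicus) for metabolic stability (a higher number here means that the compound lasts longer, a lower number that the compound disappears faster), compound 1 `Nc1nc(NCCNc2ncc(-c3ncc[nH]3)c(-c3cc(F)c(F)cc3F)n2)ccc1[N+](=O)[O-]` gives > 0.5 h, which is a limit of the assay and not a number. Compound 2 `Nc1nc(NCCNc2ncc(-c3ncc[nH]3)c(-c3ccc(Cl)cc3F)n2)ccc1[N+](=O)[O-]` gives > 0.5 h, which is also a limit and not a number. The two compounds therefore share (the limit of > 0.5 h in this assay, at which 2 of the 2 values shown sit). Among the measured compounds shown here, the only measured step is a step that the two limits leave unreadable from compound 1 to compound 2, so it offers no size to carry forward.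

Compound 3 `Nc1nc(NCCNc2ncc(-c3ncc[nH]3)c(-c3ccc(Cl)cc3Br)n2)ccc1[N+](=O)[O-]` differs from compound 2 by bromo in place of fluoro on an aromatic carbon, with bromo in place of fluoro on an aromatic carbon, ortho to a large group. For the measured compounds named here, no measured step covers this exchange, so the expectation rests on little and points in no firm direction: no shift beyond the usual scatter is expected. The estimated change is a step that the limit leaves unreadable from compound 2 to compound 3. The estimate for compound 3 is 0.6 h, with an expected range of 0.3 h to 1 h.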

Compound 3, half-life: > 0.5 h
Compound 3 gave a limit, no number (the forecaster's own chance of this, stated with the estimate: 65%); the middle value does not contradict the limit.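

Among the compounds shown here, compound 1, compound 2 and compound 3 all sit at the same limit of this assay, so no step among them can be read: the limit of > 0.5 h in this assay, at which 3 of the 3 values shown sit. Going by these compounds, how long each of the three actually lasts, and whether the exchanges between them shift that half-life, stays open.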